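Side-chain change on compound 3: cytotoxicity notes

The source may hold more compounds than are shown below. What is called first, only, known or untested is meant among the compounds shown, and "the series" means these compounds.

Values in an ADME assay on Vero cells (Chlorocebus sabaeus) for cytotoxicity, read by MTT assay, with a stated time of 72 h; a higher number here means that more compound is tolerated, a lower number that less compound is tolerated:
- compound 1 `CCOC(=O)CCN1CCN(c2c(F)cc3c(=O)c(C(=O)O)cn(C4CC4)c3c2OC)CC1C`: "not determined" (no result reported)
- compound 2 `COc1c(N2CCN(CC(C)=O)C(C)C2)c(F)cc2c(=O)c(C(=O)O)cn(C3CC3)c12`: 500 ug/mL
- compound 3 `COc1c(N2CCN(CCC(C)=O)C(C)C2)c(F)cc2c(=O)c(C(=O)O)cn(C3CC3)c12`: 9.84 ug/mL

Compound 3, at 9.84 ug/mL, holds the lowest of the two numbers available. Compound 2 stands far from it at 500 ug/mL, and compound 1 offers no number for comparison.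

The next compound to be measured is compound 4 `COc1c(N2CCN(C/C(C)=N/NC(C)=O)C(C)C2)c(F)cc2c(=O)c(C(=O)O)cn(C3CC3)c12`. Its change from compound 3 is a group of 7 heavy atoms (4 carbon, 2 nitrogen, 1 oxygen; no ring) in place of a group of 4 heavy atoms (3 carbon, 1 oxygen; no ring), on a saturated chain carbon bound to an amine nitrogen in a ring, on a saturated chain carbon bound to an amine nitrogen in a ring.

Among the measured compounds shown here, one measured step bears on this change, at the same place: a 51-fold lower number from compound 2 to compound 3 (1.71 log units; beyond the scatter). This large step shows that the number in this assay can move far with a change at this place, but a single step gives no rule for the new group. With compound 3 at the low end of the two numbers, at 9.84 ug/mL, a move upward of moderate size is expected, with wide uncertainty.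

The estimate means an expected 6.1-fold higher number from compound 3 to compound 4 (0.79 log units; beyond the scatter). For compound 4 the expected value is 60 ug/mL, with an estimated range from 10 ug/mL to 500 ug/mL.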

Compound 4, half-maximal cytotoxic concentration: 707 ug/mL
For compound 4 the middle estimate is 12-fold (1.07 log units) below the measured one; the measured number lies above the stated range.
By their numbers in this assay, from the lowest: compound 3; then compounds 2 and 4 (each within the scatter of the next).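

In this assay, the low number of compound 3 does not hold when the 2-oxopropyl group gives way to the group of 7 heavy atoms, a step of a 72-fold higher number from compound 3 to compound 4 (1.86 log units; beyond the scatter). The earlier step showed only a fall at this place; the new data show that the number can also rise far there, and the larger group leaves the result level with the acetyl-bearing compound, at a 1.4-fold higher number from compound 2 to compound 4 (0.15 log units; within the scatter). Nothing here gives a measured reason for this swing.

Still open, as far as these compounds go, is whether the low number is tied to the 2-oxopropyl group alone. A longer ketone chain, or an amine or a carboxylic acid at the end of the chain on this ring nitrogen, would test how narrow that result is.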